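Ester in place of the acid end of compound 2

The source may report more compounds than this note shows. Statements on the series, on what has been measured and on what is new or still open speak of the compounds shown alone.

Measured so far:
compound 1, `Cc1cn([C@@H]2O[C@H](CO[Si](C)(C)C(C)(C)C)[C@@]3(OS(=O)(=O)C=C3NCC(=O)C(=O)N3CCC3)[C@H]2O[Si](C)(C)C(C)(C)C)c(=O)n(C)c1=O`: 21600 nM
compound 2, `Cc1cn([C@@H]2O[C@H](CO[Si](C)(C)C(C)(C)C)[C@@]3(OS(=O)(=O)C=C3NCC(=O)C(=O)O)[C@H]2O[Si](C)(C)C(C)(C)C)c(=O)n(C)c1=O`: 72600 nM

Both compounds were tested in a functional assay on CCRF-CEM cells (Homo sapiens); on this read-out lower numbers stand for higher toxicity in this test and higher numbers for lower toxicity in this test. Compound 2 gives the highest of the two numbers, and its nearest neighbour is compound 1, separated by a 3.4-fold higher number from compound 1 to compound 2 (0.53 log units; beyond the scatter), a modest step that lies beyond the scatter. That step is the only one available and it concerns the same carbonyl end of the chain: exchanging the azetidinyl amide for the free acid raised the number.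

Compound 3, `COC(=O)CCNC1=CS(=O)(=O)O[C@@]12[C@@H](CO[Si](C)(C)C(C)(C)C)O[C@@H](n1cc(C)c(=O)n(C)c1=O)[C@@H]2O[Si](C)(C)C(C)(C)C`, is not yet measured. Against compound 2 the change is (methoxycarbonyl)methyl in place of carboxycarbonyl on a saturated chain carbon bound to an amine nitrogen. The acid is gone and an ester stands in its place, so the one donor of the entering-and-leaving pair disappears while the acceptor count stays. Compound 1, which also lacks the acid, sits lower than compound 2; by that single comparison, compound 3 is expected to move back toward compound 1 by about a 2.3-fold lower number from compound 2 to compound 3 (0.36 log units; beyond the scatter), a modest step downward. The estimate for compound 3 in this assay is 32000 nM, with a range from 11000 nM to 95000 nM.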

Compound 3, half-maximal cytotoxic concentration: > 250000 nM
Compound 3: only a limit was reported; the forecaster's own chance of this, stated with the estimate: 15%; middle value at least 7.8-fold (0.89 log units) from the limit.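

In this assay compound 3 gives no number, only a limit: the limit of > 250000 nM in this assay, at which 1 of the 3 values shown sits. Even so, the direction of the change on the saturated chain carbon bound to an amine nitrogen can be read, with an at least 3.4-fold higher number from compound 2 to compound 3 (0.53 log units; beyond the scatter) and, for the wider exchange of the amide end, an at least 11-fold higher number from compound 1 to compound 3 (1.06 log units; beyond the scatter). Among the compounds shown here, compound 1 and compound 2 showed only that the group on the carbonyl end shifts the number modestly, whereas this result shows that the absence of the acid does not by itself bring a compound back toward compound 1, since compound 1 and compound 3 both lack it and lie far apart in this assay.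

The change from carboxycarbonyl to (methoxycarbonyl)methyl removes the hydrogen-bond donor and a double bond outside aromatic rings together, so the compounds shown cannot assign the rise to either, and a methyl ester on the carboxycarbonyl end or a free carboxylic acid on the 2-(methoxycarbonyl)ethyl chain would separate the two. From the compounds shown here alone, how far compound 3 lies past its limit also remains open, as does whether a shorter chain or an amine at the chain end would behave the same way.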